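The compounds below may be only part of what the source reports. "The series", "measured", "known", "first", "only" and "open" are said of these compounds alone.

Of the compounds shown here, three from this series have been measured in a functional assay on NCI-H460 cells (Homo sapiens) for cytotoxicity, read by MTT assay, with a stated time of 72 h; a lower number here means a stronger inhibitor, a higher number a weaker inhibitor. Compound 1 `CN(C)CCCNc1nc(-c2ccc(NC(=O)Nc3ccccc3F)cc2)nc2ccsc12` gives 530 nM, and compound 2 `CN(C)CCNc1nc(-c2ccc(NC(=O)Nc3ccccc3F)cc2)nc2ccsc12` gives 410 nM. These two differ only in the length of the chain carrying the basic amine, and the step of a 1.3-fold lower number from compound 1 to compound 2 (0.11 log units; within the scatter) is small. Compound 3 `CCN(CC)CCCNc1nc(-c2ccc(NC(=O)Nc3ccc(F)cc3)cc2)nc2ccsc12` gives 290 nM, the lowest of the three numbers, although its gaps to compound 2 and to compound 1 both fall within the usual scatter, so no ranking among them can be claimed.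

Compound 4 `CCN(CC)CCCNc1nc(-c2ccc(NC(=O)Nc3ccccc3F)cc2)nc2ccsc12` is the next compound. It differs from compound 3 by 2-fluorophenyl in place of 4-fluorophenyl on an amide-type nitrogen. Among the measured compounds shown here, no measured pair isolates this particular change: compound 1 and compound 2 already carry the 2-fluorophenyl group, but they also carry a different amine on the chain, so their values cannot be set against compound 3 as a clean comparison. For the measured compounds named here, the one measured step, from compound 1 to compound 2, concerns the chain rather than the fluorophenyl group. With nothing directly bearing on the change, the expectation for compound 4 is a step of a 1.3-fold higher number from compound 3 to compound 4 (0.12 log units; within the scatter) that stays within the scatter. Compound 4 is therefore estimated at 380 nM, with a plausible range from 180 nM to 800 nM.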

Compound 4, half-maximal inhibitory concentration: 370 nM
Compound 4: middle estimate off by 1.0-fold (0.01 log units), on the high side, within the range that was stated.
By their numbers in this assay, from the lowest: compounds 3, 4, 2 and 1 (each within the scatter of the next).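

Setting 2-fluorophenyl in place of 4-fluorophenyl on the amide-type nitrogen gives a 1.3-fold higher number from compound 3 to compound 4 (0.11 log units; within the scatter) and is the first direct test of where the fluorine sits on this ring: here the two placements cannot be told apart. Compound 4 also allows a clean look at the amine end of the chain, where diethylamino in place of dimethylamino gives a 1.4-fold lower number from compound 1 to compound 4 (0.16 log units; within the scatter) and the change that alters both the amine and the chain length gives a 1.1-fold lower number from compound 2 to compound 4 (0.04 log units; within the scatter) so, among these four compounds, neither the fluorine's place nor the amine end produces a step beyond the scatter. No outside measurement is available to explain these small steps.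

Going by these compounds, whether a 3-fluorophenyl, an unsubstituted phenyl or a chlorophenyl group on the same nitrogen would also stay within the scatter remains open. So does the question of whether a ring amine such as morpholine or piperidine at the end of the chain, or a longer chain, would change the number by more than the scatter.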